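Aryl swap at the biaryl terminus: chlorine for methyl

The source may report more compounds than this note shows. Statements on the series, on what has been measured and on what is new or still open speak of the compounds shown alone.

Compound 1 `CC[C@@H](Nc1c(C#N)c(-c2ccc(-c3cccc(C)c3)cc2)nc2cnccc12)C(N)=O` gives 3 in a physicochemical assay for lipophilicity, read by HPLC, at pH 7.5; on this read-out higher numbers stand for higher lipophilicity and lower numbers for lower lipophilicity. Compound 3 `CCOc1ccccc1-c1ccc(-c2nc3cnccc3c(C[C@H](C)C(N)=O)c2C#N)cc1` gives 3 in this assay, level with compound 1 at the digits shown and within the scatter; together these two are the highest of the three numbers. Compound 2 `CCOc1ccccc1-c1ccc(-c2nc(NC(C)C(=O)O)c3ccncc3n2)cc1`, the one bearing a carboxylic acid, gives 2.1, lower than compound 1 by a margin beyond the scatter. Compound 4 `CC[C@@H](Nc1c(C#N)c(-c2ccc(-c3ccccc3Cl)cc2)nc2cnccc12)C(N)=O` is not yet measured. It differs from compound 1 in one place: 2-chlorophenyl in place of 3-methylphenyl on an aromatic carbon. Methyl and chlorine on an aromatic ring have given similar readings in this kind of assay elsewhere, so the step from compound 1 to compound 4 is expected to be small, a number 0.10 log units higher from compound 1 to compound 4 (within the scatter), not beyond the scatter. Compound 4 is therefore estimated at 3.1, with a range from 2.7 to 3.5.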

Compound 4, distribution coefficient: 2.9
The estimate for compound 4 lay 0.20 log units above the measured number; measured number inside the range.
By their numbers in this assay, from the lowest: compound 2; then compounds 4, 1 and 3 (each within the scatter of the next).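

Within the data shown here, at this aromatic carbon, para to a large group, 2-chlorophenyl and 3-methylphenyl read alike in this assay (a number 0.10 log units lower from compound 1 to compound 4 (within the scatter)), the first single-place comparison. The exchange alters both the ring substituent and where it sits, yet the step stays within the scatter. Nothing measured explains this equivalence.

The swap leaves the two changes unseparated: 3-chlorophenyl or 2-methylphenyl would read each one alone. On these data alone, an amine or a carboxylic acid on this terminal ring also remains open.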